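This account rests on a few compounds, and the source may have more. Where it says the series, first, only, none or still open, it means among the compounds named here.

In a functional assay on A549 cells (Homo sapiens) for antiproliferative activity, read by MTT assay, with a stated time of 48 h (a higher number here means a weaker inhibitor, a lower number a stronger inhibitor), compound 1 `COc1ccc2c(/C=C/C(=O)c3cc(OC)c(OC)c(SC)c3)c[nH]c2c1` gives 115 nM and compound 3 `COc1ccc2c(/C=C/C(=O)c3cc(OC)c(OC)c(SC)c3)cn(C)c2c1` gives 156 nM while compound 2 `COc1ccc2c(/C=C(\C)C(=O)c3cc(OC)c(OC)c([Se]C)c3)cn(C)c2c1` gives 15 nM as the lowest of the three numbers, beyond the scatter from both others. Compound 4 `COc1ccc2c(/C=C(\C)C(=O)c3cc(OC)c(OC)c([Se]C)c3)c[nH]c2c1` differs from compound 2 by hydrogen in place of methyl on an aromatic nitrogen with hydrogen in place of methyl on an aromatic nitrogen. For the measured compounds named here, the only measured step of this kind runs the opposite way: a 1.4-fold higher number from compound 1 to compound 3 (0.13 log units; within the scatter) is methyl in place of hydrogen on an aromatic nitrogen and lies within the scatter. It comes from a different pair, so it is only a guide. Read backwards, it points to no change beyond the scatter, so a 1.2-fold lower number from compound 2 to compound 4 (0.06 log units; within the scatter) is the expected step in this assay and stays within the scatter. Compound 4 is estimated at 13 nM with 6 nM to 32 nM as the expected range.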

Compound 4, half-maximal inhibitory concentration: 8 nM
Compound 4: middle estimate off by 1.6-fold (0.21 log units), on the high side, and the stated range covers the measured number.
By their numbers in this assay, from the lowest: compounds 4 and 2 (each within the scatter of the next); then compounds 1 and 3 (each within the scatter of the next).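

Hydrogen in place of methyl on the aromatic nitrogen gives a 1.9-fold lower number from compound 2 to compound 4 (0.27 log units; within the scatter), so on this second core too, neither group at this position moves the number beyond the scatter. The position now has readings on two cores, and they agree: the same change on two cores in this assay, a 1.4-fold higher number (0.13 log units; within the scatter) from compound 1 to compound 3 and a 1.9-fold higher number (0.27 log units; within the scatter) from compound 4 to compound 2, 1.4-fold (0.14 log units) apart, within the scatter of two such steps

Only hydrogen and methyl are shown on this nitrogen, so it remains open whether an ethyl group, a longer chain or an acetyl group would be tolerated there. Compound 2 and compound 3 differ in more than one place, so the compounds shown do not tell which difference goes with the gap between their numbers.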